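A few compounds are considered here, and "the series" means these few. Any claim that something is new, unique, unknown or untested is made for them only; others in the source may bear on it.

Measured compounds:
- compound 1, `COc1ccc(/C=C2/N=C(c3ccccc3)N(C(=O)c3ccc(C)cc3)NC2=O)cc1`: in a functional assay on the whole organism (strain albino) with Mus musculus as the target, with a stated time of 0.5 h (on this read-out lower numbers stand for an effect already at smaller amounts and higher numbers for an effect only at larger amounts of compound), compound 1 gives 30 mg/kg
- compound 2, `O=C1NN(C(=O)c2ccccc2Cl)C(c2ccccc2)=N/C1=C/c1ccccc1Cl`: in this assay compound 2 gives 30 mg/kg
- compound 3, `COc1ccc(/C=C2/N=C(c3ccccc3)N(C(=O)c3ccc(Cl)cc3)NC2=O)cc1`: in this assay compound 3 gives 100 mg/kg

Compound 3 stands at the highest of the three numbers. Among the compounds with values here, its nearest neighbour is compound 1, separated by the step of a 3.3-fold higher number from compound 1 to compound 3 (0.52 log units; beyond the scatter), and compound 2 sits equally far below compound 3, although the two differ in more than one place, so no single step can be drawn between them.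

Compound 4, `O=C1NN(C(=O)c2ccc(Cl)cc2)C(c2ccccc2)=N/C1=C/c1ccccc1`, is compound 3 with one change: hydrogen in place of methoxy on an aromatic carbon. Within the data shown here, the only measured step, a 3.3-fold higher number from compound 1 to compound 3 (0.52 log units; beyond the scatter), concerns a different group at a different place, and the gap between compound 2 and compound 3 cannot be tied to any one change. Among the measured compounds shown here, no measured step therefore bears on the removal of the methoxy group, and there is no ground to expect a shift beyond the scatter in either direction.

For compound 4 the expected value in this assay is 80 mg/kg, with a range from 30 mg/kg to 250 mg/kg, and the estimated step is a 1.3-fold lower number from compound 3 to compound 4 (0.10 log units; within the scatter).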

Compound 4, dose for half-maximal effect: 100 mg/kg
Compound 4: middle estimate off by 1.3-fold (0.10 log units), on the low side; the measured number falls inside the stated range.
By their numbers in this assay, from the lowest: compounds 1 and 2 (each within the scatter of the next); then compounds 3 and 4 (each within the scatter of the next).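

Replacing methoxy with hydrogen on this aromatic carbon, para to a large group, gives no change at the digits printed from compound 3 to compound 4 (within the scatter) in this assay. Within the data shown here, this is the first look at this position, since the only earlier step concerned the swap of methyl for chloro at a different place. With the chloro in place, the shared core can therefore lose the methoxy group, with its 2 heavy atoms and 1 hydrogen-bond acceptor, without a shift beyond the scatter, and nothing measured here offers an explanation for this result.

The compounds shown cover only the 4-methoxyphenyl to phenyl change at this position, so it remains open whether an amine, a carboxylic acid or a longer chain such as butoxy in the same place would also leave the number within the scatter. From the compounds shown here alone, it also remains open whether removing the methoxy group would read the same with the methyl of compound 1 in place of the chloro, given that this swap alone produced a shift beyond the scatter.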